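The source may hold more compounds than are shown below. What is called first, only, known or untested is meant among the compounds shown, and "the series" means these compounds.

Measured in a functional assay on KYSE-450 cells (Homo sapiens) for inhibition, read by MTT assay, with a stated time of 48 h; on this read-out higher numbers stand for weaker inhibition and lower numbers for stronger inhibition:
- compound 1 `C/C=C/C(=O)N(Cc1ccc(OC)c([N+](=O)[O-])c1)c1cc(OC)c(OC)c(OC)c1`: 510 nM
- compound 2 `C/C=C/C(=O)N(Cc1ccc(OC)c(C)c1)c1cc(OC)c(OC)c(OC)c1`: 32900 nM
- compound 3 `C/C=C/C(=O)N(Cc1ccc(OC)c(O)c1)c1cc(OC)c(OC)c(OC)c1`: 67 nM

Compound 3 has the lowest number of the three, which means the strongest inhibition in this assay. Compound 4 `C/C=C/C(=O)N(Cc1ccc(OC)cc1)c1cc(OC)c(OC)c(OC)c1` differs from it in one place: hydrogen in place of hydroxy on an aromatic carbon. This puts hydrogen in place of hydroxy on an aromatic carbon, turning 3-hydroxy-4-methoxyphenyl into 4-methoxyphenyl.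

Among the measured compounds shown here, no measured step makes this exact swap, but three steps concern the same aromatic carbon. Arriving at the hydroxy of compound 3 lowered the number both times: a 7.6-fold lower number from compound 1 to compound 3 (0.88 log units; beyond the scatter) and a 490-fold lower number from compound 2 to compound 3 (2.69 log units; beyond the scatter). The remaining step, a 65-fold higher number from compound 1 to compound 2 (1.81 log units; beyond the scatter), shows that the size of the loss depends heavily on which group stands there. Hydrogen has not been measured at this carbon, so the range stays wide, but a clear rise is expected in this assay. The estimated step is a 60-fold higher number from compound 3 to compound 4 (1.78 log units; beyond the scatter). Compound 4 is estimated at 4000 nM, with an expected range of 400 nM to 30000 nM.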

Compound 4, half-maximal inhibitory concentration: 420 nM
Beside the measured number, compound 4's estimate is 9.5-fold (0.98 log units) above it; low and high end bracket the measured number.
By their numbers in this assay, from the lowest: compound 3; then compounds 4 and 1 (each within the scatter of the next); then compound 2.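

Hydrogen gives this carbon a plain reference point. In this assay, taking the hydroxy away gives a 6.3-fold higher number from compound 3 to compound 4 (0.80 log units; beyond the scatter), so the hydroxy holds only a modest advantage over the bare ring carbon. The methyl stands far from that reference, with a 78-fold lower number from compound 2 to compound 4 (1.89 log units; beyond the scatter), which shows that most of the wide gap between compound 2 and compound 3 lies on the methyl side, while a 1.2-fold lower number from compound 1 to compound 4 (0.08 log units; within the scatter) leaves nitro and hydrogen indistinguishable here. The compounds shown leave open whether an amine, a fluorine atom or a longer ether such as ethoxy at this carbon would match the hydroxy or fall as far as the methyl. No measurement available here explains why these groups differ.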